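Changing the Aryl Group on the Ring Amine Nitrogen

The source may report more compounds than this note shows. Statements on the series, on what has been measured and on what is new or still open speak of the compounds shown alone.

Measured so far:
Compound 1, `COc1ccccc1N1CCN(C[C@@H](O)COc2ccc(F)cc2)CC1`, gives 50.7%
Compound 2, `O[C@H](COc1ccc(C(F)(F)F)cc1)CN1CCN(c2ccc(F)cc2)CC1`, gives 59.2%
Compound 3, `COc1ccccc1N1CCN(C[C@@H](O)COc2ccc(Cl)cc2)CC1`, gives 47.4%

All three were tested in an assay on HEK293 cells for inhibition of Voltage-dependent T-type calcium channel subunit alpha-1G (Homo sapiens), read by patch clamp, tested at 10 uM; on this read-out lower numbers stand for less inhibition and higher numbers for more inhibition at the one concentration tested (going by the name of the read-out). Compound 1 stands second highest of the three numbers; compound 3 is nearest and compound 2 furthest, and both gaps lie within the usual scatter, so the three compounds cannot be told apart on these values. Within the data shown here, the only measured step between neighbours, a number 3.3 percentage points lower from compound 1 to compound 3 (within the scatter), was itself within the scatter.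

Compound 4, `O[C@@H](COc1ccc(F)cc1)CN1CCN(c2ccc(F)cc2)CC1`, has not yet been measured. It differs from compound 1 by 4-fluorophenyl in place of 2-methoxyphenyl on an amine nitrogen in a ring. Among the measured compounds shown here, no measured step isolates exactly this change. Compound 2 carries the same 4-fluorophenyl on the ring nitrogen, and in this assay compound 2 gives 59.2%, which sits within the scatter of compound 1.

Because a number 3.3 percentage points lower from compound 1 to compound 3 (within the scatter) was small and the value of compound 2 is close, no step beyond the scatter is expected for compound 4: the estimated change is a number 4.3 percentage points higher from compound 1 to compound 4 (within the scatter). Compound 4 is therefore expected at 55%, in a range from 40% to 70%.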

Compound 4, a percentage reported as inhibition, at one concentration (the size of the read-out at that concentration, not a potency): 47.5%
Compound 4: middle estimate off by 7.5 percentage points, on the high side; low and high end bracket the measured number.
By their numbers in this assay, from the lowest: compounds 3, 4, 1 and 2 (each within the scatter of the next, the first and the last beyond it).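

In this assay, among these compounds, putting 4-fluorophenyl in place of 2-methoxyphenyl on the amine nitrogen in the ring gives a number 3.2 percentage points lower from compound 1 to compound 4 (within the scatter), the first measured step at this position, and it stays within the scatter. The group that leaves carries a hydrogen-bond acceptor and the group that enters carries none, yet compound 1 and compound 4 cannot be told apart on this read-out, so at this single concentration the inhibition in this assay is level across this exchange of aryl groups. No independent measurement is available to explain this result.

From the compounds shown here alone, whether any group on this ring nitrogen can shift the inhibition beyond the scatter remains open, for example a phenyl ring bearing a nitrile or a carboxylic acid. Going by these compounds, because all these numbers come from one concentration, potency also remains open.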